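Dichlorophenyl Variant in a Cytotoxicity Series

The source may report more compounds than this note shows. Statements on the series, on what has been measured and on what is new or still open speak of the compounds shown alone.

Compound 1 `Cc1cccc(C(O)c2cc(Cl)ccc2OCC(=O)Nc2ccc(S(N)(=O)=O)cc2C)c1` gives 33200 nM in an ADME assay on C8166 cells (Homo sapiens) for cytotoxicity, read by MTT assay (on this read-out lower numbers stand for higher toxicity in this test and higher numbers for lower toxicity in this test), the lowest of the three numbers shown, though compound 3 `Cc1ccc(C)c(C(O)c2cc(Cl)ccc2OCC(=O)Nc2ccc(S(N)(=O)=O)cc2C)c1` with 35500 nM and compound 2 `Cc1cc(S(N)(=O)=O)ccc1NC(=O)COc1ccc(Cl)cc1C(O)c1cccc(F)c1` with 37600 nM both lie within the scatter of it. The three measured steps, a 1.1-fold higher number from compound 1 to compound 2 (0.05 log units; within the scatter), a 1.1-fold higher number from compound 1 to compound 3 (0.03 log units; within the scatter) and a 1.1-fold lower number from compound 2 to compound 3 (0.02 log units; within the scatter), all vary the aryl ring on the saturated chain carbon, and each stays within the scatter. Compound 4 `Cc1cc(S(N)(=O)=O)ccc1NC(=O)COc1ccc(Cl)cc1C(O)c1cc(Cl)cc(Cl)c1` differs from compound 1 by 3,5-dichlorophenyl in place of 3-methylphenyl on a saturated chain carbon bound to an aromatic carbon and an oxygen on a saturated carbon. Because the steps of a 1.1-fold higher number from compound 1 to compound 2 (0.05 log units; within the scatter) and a 1.1-fold lower number from compound 2 to compound 3 (0.02 log units; within the scatter) at this same place stayed within the scatter, no step beyond the scatter is expected here either. Compound 4 is therefore expected to give 30000 nM, between 15000 nM and 60000 nM, meaning a step of a 1.1-fold lower number from compound 1 to compound 4 (0.04 log units; within the scatter).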

Compound 4, half-maximal cytotoxic concentration: 13100 nM
Estimate against measurement, compound 4: 2.3-fold (0.36 log units) above, and the stated range ends above it.
By their numbers in this assay, from the lowest: compound 4; then compounds 1, 3 and 2 (each within the scatter of the next).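

In this assay, within the data shown here, the 3,5-dichlorophenyl group is the first ring at this place to move the number beyond the scatter, with a 2.5-fold lower number from compound 1 to compound 4 (0.40 log units; beyond the scatter) and a 2.7-fold lower number from compound 3 to compound 4 (0.43 log units; beyond the scatter) and a 2.9-fold lower number from compound 2 to compound 4 (0.46 log units; beyond the scatter) all pointing to higher toxicity in this test. The position is therefore not indifferent to the aryl ring, although 3-methylphenyl, 3-fluorophenyl and 2,5-dimethylphenyl could not be told apart. The compounds shown leave open whether a pyridine ring or a phenyl ring carrying a carboxylic acid would shift the number at this place. Nothing at hand explains the step.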